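Swapping the amine-bearing chain for a benzyl group on compound 1

A few compounds are considered here, and "the series" means these few. Any claim that something is new, unique, unknown or untested is made for them only; others in the source may bear on it.

Compound 1 `CN(C)CCCn1c(=O)n(C2OC(CO)[C@@H](O)[C@H]2O)c2nc(N)nc(O)c21` is tested in a functional assay on the whole organism (B cells) with Mus musculus as the target (a lower number here means a smaller maximal response, a higher number a larger maximal response), where compound 1 reaches 83%. Among the three measured compounds it stands second highest: compound 3 `C=CCn1c(=S)n(C2OC(CO)[C@@H](O)[C@H]2O)c2nc(N)nc(O)c21` reaches 100% in this assay, a value beyond the scatter above compound 1, while compound 2 `C=CCn1c(=O)n(C2OC(CO[Si](C)(C)C(C)(C)C)[C@@H](O)[C@H]2O)c2nc(N)nc(O)c21` reaches 5%, far below compound 1. Among the compounds with values here, no single-point step between these measured compounds is available, so their values are only compared as they stand. Compound 4 `Nc1nc(O)c2c(n1)n(C1OC(CO)[C@@H](O)[C@H]1O)c(=O)n2Cc1ccccc1` is not yet measured. It differs from compound 1 in one place (phenyl in place of 2-(dimethylamino)ethyl on a saturated chain carbon bound to an aromatic nitrogen), on a saturated chain carbon bound to an aromatic nitrogen. As far as these compounds go, because compound 1 gives 83% while a benzyl group in this position is untested here, the step from compound 1 to compound 4 is expected to be a small decrease, possibly not beyond the scatter, amounting to a number 13 percentage points lower from compound 1 to compound 4 (beyond the scatter). Compound 4 is therefore estimated to reach 70% in this assay, within a range from 35% to 100%.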

Compound 4, largest response reached (reported as maximal response), in percent of the reference or control that the assay uses: 110%
Estimate against measurement, compound 4: 40 percentage points below; measured number outside the range, above it.
By their numbers in this assay, from the lowest: compound 2; then compound 1; then compounds 3 and 4 (each within the scatter of the next).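

Within the data shown here, the single step at this position is a rise in this assay, with a number 27 percentage points higher from compound 1 to compound 4 (beyond the scatter) when 3-(dimethylamino)propyl gives way to benzyl. Among these compounds, on this pair, the chain's amine nitrogen is therefore not required for a high maximal response, and an aromatic ring of carbon only on a saturated chain carbon bound to an aromatic nitrogen is compatible with one, something the earlier compounds could not show since none of them formed a single-place pair. Nothing available explains why the response rises.

The compounds shown leave open whether the gain depends on the phenyl ring itself or simply on removing the dimethylamino group, which a plain propyl chain could separate. They also leave open how a benzyl ring carrying a fluorine, a methoxy group or a carboxylic acid, or a longer phenylpropyl chain, would behave here.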